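Hydrazone aryl variation on the shared core: working notes

The source may report more compounds than this note shows. Statements on the series, on what has been measured and on what is new or still open speak of the compounds shown alone.

Three measured analogues share one core and differ only in the aryl group of the hydrazone. Compound 1 `O=C(CCc1nc2ccccc2c(=O)[nH]1)N/N=C/c1ccc(Cl)cc1` gives 381000000 nM in a physicochemical assay, read by spectrophotometry, with a stated time of 30 min; on this read-out higher numbers stand for weaker inhibition and lower numbers for stronger inhibition. Compound 2 `O=C(CCc1nc2ccccc2c(=O)[nH]1)N/N=C/c1ccc([N+](=O)[O-])cc1` gives 328000000 nM in this assay, and the change is a 1.2-fold lower number from compound 1 to compound 2 (0.07 log units; within the scatter). Compound 3 `O=C(CCc1nc2ccccc2c(=O)[nH]1)N/N=C/c1cc(O)c(O)c(O)c1` gives 81000000 nM, the lowest of the three numbers, reached by a 4.7-fold lower number from compound 1 to compound 3 (0.67 log units; beyond the scatter) and by a 4.0-fold lower number from compound 2 to compound 3 (0.61 log units; beyond the scatter).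

Compound 4 `O=C(CCc1nc2ccccc2c(=O)[nH]1)N/N=C/c1ccc(O)cc1` is the next step from compound 3: 4-hydroxyphenyl in place of 3,4,5-trihydroxyphenyl on a carbon with a double bond to nitrogen. For the measured compounds named here, no measured step removes two hydroxyls while keeping one, so only the two steps reaching compound 3 bear on it. Both of those steps were modest and beyond the scatter, and compound 4 keeps only one of the three hydroxyls, so a number between compound 3 and compounds 1 and 2 is expected. The step expected here is a 2.5-fold higher number from compound 3 to compound 4 (0.39 log units; beyond the scatter), toward a higher number. For compound 4 the estimate in this assay is 200000000 nM, with a range from 100000000 nM to 400000000 nM.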

Compound 4, half-maximal inhibitory concentration: 238000000 nM
Beside the measured number, compound 4's estimate is 1.2-fold (0.08 log units) below it; the range from low to high includes it.
By their numbers in this assay, from the lowest: compound 3; then compounds 4, 2 and 1 (each within the scatter of the next).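

In this assay, the change to 4-hydroxyphenyl on a carbon with a double bond to nitrogen gives a 2.9-fold higher number from compound 3 to compound 4 (0.47 log units; beyond the scatter), so a single hydroxyl does not hold the number reached with 3,4,5-trihydroxyphenyl. Hydroxy on an aromatic carbon also does not separate from nitro or chloro, with a 1.4-fold lower number from compound 2 to compound 4 (0.14 log units; within the scatter) and a 1.6-fold lower number from compound 1 to compound 4 (0.20 log units; within the scatter), which leaves 3,4,5-trihydroxyphenyl as the only aryl group of the four set apart from the others. Nothing available accounts for this difference.

From the compounds shown here alone, whether the low number needs all three hydroxyls remains open, and a 3,4-dihydroxyphenyl group would bear directly on that. Going by these compounds, it is also open whether the hydroxyl itself matters, which methoxy groups in its place on the same ring, or an amine or a carboxylic acid there, could test.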